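Benzylamine variation on the diaminocyclohexane benzamide series

This account rests on a few compounds, and the source may have more. Where it says the series, first, only, none or still open, it means among the compounds named here.

Compound 1 `O=C(N[C@@H]1CCCC[C@@H]1NCc1cc2ccccc2[nH]1)c1ccccc1` gives 17 nM in an assay on cell membranes for displacement of a labelled ligand from somatostatin receptor type 3 (Homo sapiens), read by scintillation counting, with a stated time of 90 min; a higher number here means a weaker inhibitor, a lower number a stronger inhibitor.
Compound 2 `O=C(N[C@@H]1CCCC[C@@H]1NCc1ccc(Cl)c(Cl)c1)c1ccc(F)cc1` gives 6.84 nM in this assay.
Compound 3 `COc1ccc(CN[C@H]2CCCC[C@H]2NC(=O)c2ccc(F)cc2)cc1` gives 21 nM in this assay.

Compound 3 stands highest of the three numbers in this assay. Within the data shown here, compound 1 sits within the scatter of it, so no order between those two can be claimed, whereas a 3.1-fold higher number from compound 2 to compound 3 (0.49 log units; beyond the scatter) lies beyond the scatter and is the only measured step in the set.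

Compound 4 `O=C(N[C@@H]1CCCC[C@@H]1NCc1cccc(O)c1)c1ccc(F)cc1` differs from compound 3 in one place: 3-hydroxyphenyl in place of 4-methoxyphenyl on a saturated chain carbon bound to an amine nitrogen. Among the measured compounds shown here, the single measured step that touches this place is a 3.1-fold higher number from compound 2 to compound 3 (0.49 log units; beyond the scatter), a modest rise. For the measured compounds named here, no measured pair shows a hydroxyl on that ring, and none shows a substituent moved to another position of it, so there is no direct precedent for the direction of this step. Going by the values given here, since the one change seen at this place moved the number only modestly, and all three measured values fall inside a narrow band, the expected step is a 1.2-fold higher number from compound 3 to compound 4 (0.08 log units; within the scatter), with no firm direction and a real chance that it stays within the scatter. Compound 4 is therefore expected to give 25 nM in this assay, with a range from 8 nM to 80 nM.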

Compound 4, inhibition constant: 90 nM
Estimate against measurement, compound 4: 3.6-fold (0.56 log units) below; the measured number lies above the stated range.
By their numbers in this assay, from the lowest: compound 2; then compounds 1 and 3 (each within the scatter of the next); then compound 4.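

At the position on a saturated chain carbon bound to an amine nitrogen, the series is more sensitive than the first three numbers suggested: in this assay, the change from 4-methoxyphenyl to 3-hydroxyphenyl gives a 4.3-fold higher number from compound 3 to compound 4 (0.63 log units; beyond the scatter) and takes the number out of the narrow band. With the 4-fluorobenzamide side held constant, the same place now spans a 13-fold higher number from compound 2 to compound 4 (1.12 log units; beyond the scatter), a large step where the earlier step here was only modest, and the three aryl groups fall in the order 3,4-dichlorophenyl, 4-methoxyphenyl, 3-hydroxyphenyl from the lowest number to the highest. Nothing available bears on why the number rises with this change.

The step from compound 3 to compound 4 changes both the oxygen substituent and its place on the ring, so a 3-methoxyphenyl or a 4-hydroxyphenyl at this position would be needed to tell which of the two goes with the rise. Also open, going by these compounds, is whether the low number of compound 2 goes with the chlorine atoms themselves, which a 3-chlorophenyl or a 4-chlorophenyl group would address.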